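The source may report more compounds than this note shows. Statements on the series, on what has been measured and on what is new or still open speak of the compounds shown alone.

Compound 1 `CCCn1ccc2cc(-c3cn[nH]c3)cc(Cl)c2c1=O` gives 65% in a functional assay on CHO cells for agonist activity at metabotropic glutamate receptor 2 (Homo sapiens), read by GTPgammaS binding; on this read-out higher numbers stand for larger maximal responses and lower numbers for smaller maximal responses.
Compound 2 `CCCn1ccc2cc(OCc3cccnc3)cc(Cl)c2c1=O` gives 126%.
Compound 3 `CCCn1ccc2cc(OCCc3cccnc3)cc(Cl)c2c1=O` gives 47%.

Compound 3 stands lowest of the three in this assay; compound 1 lies nearest to it and compound 2 farthest, both beyond the scatter. Compound 4 `CCCn1ccc2cc(OCCCc3cccnc3)cc(Cl)c2c1=O` differs from compound 3 in one place: (pyridin-3-yl)methyl in place of pyridin-3-yl on a saturated chain carbon, two bonds along the chain from an oxygen on an aromatic ring. For the measured compounds named here, the only measured step that bears on this change is a number 79 percentage points lower from compound 2 to compound 3 (beyond the scatter), a large fall on the earlier lengthening of this same chain. A further lengthening of the same kind is therefore expected to lower the maximal response again, though with less room left below compound 3, so the step of a number 17 percentage points lower from compound 3 to compound 4 (beyond the scatter) is expected to be moderate and downward. Compound 4 is thus estimated at 30%, with a range from 5% to 65%.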

Compound 4, largest response reached (Emax), in percent of the reference or control that the assay uses: 75%
The estimate for compound 4 lay 45 percentage points below the measured number, and the stated range ends below it.
By their numbers in this assay, from the lowest: compound 3; then compounds 1 and 4 (each within the scatter of the next); then compound 2.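

Lengthening the chain does not lower the response steadily in this assay: the step of a number 28 percentage points higher from compound 3 to compound 4 (beyond the scatter) runs against the earlier step of a number 79 percentage points lower from compound 2 to compound 3 (beyond the scatter), so compound 3 forms a low point among these three ethers. The longest chain still does not recover the response of the shortest, with a number 51 percentage points lower from compound 2 to compound 4 (beyond the scatter). Nothing available explains this turn. As far as these compounds go, whether a longer chain carrying the same pyridin-3-yl would rise further or fall again remains open. So does whether a phenyl or a terminal amine in place of pyridin-3-yl would follow the same course.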